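This account rests on a few compounds, and the source may have more. Where it says the series, first, only, none or still open, it means among the compounds named here.

Values so far in an in vitro ADME assay on microsomes from liver (Homo sapiens) for metabolic stability, tested at 1 uM (a lower number here means that the compound disappears faster, a higher number that the compound lasts longer), for three compounds
- Compound 1 `COc1ccc(-c2cc(-c3ccc(S(C)(=O)=O)cc3)cnc2N)cn1` gives > 1.65 h
- Compound 2 `Cc1ccc(-c2cc(-c3ccc(S(C)(=O)=O)cc3)cnc2N)cn1` gives > 5.83 h
- Compound 3 `CS(=O)(=O)c1ccc(-c2cnc(N)c(-c3ccc(C#N)cc3)c2)cc1` gives > 5.83 h

Each of these values is a limit and not a number. Compound 3 stands at the limit of > 5.83 h in this assay, at which 2 of the 3 values shown sit, and so offers no exact half-life as a starting point. Among the measured compounds shown here, compound 4 `CS(=O)(=O)c1ccc(-c2cnc(N)c(-c3ccc(C(N)=O)cc3)c2)cc1`, not yet measured, has carbamoyl in place of cyano on an aromatic carbon as its only change. The nearest measured changes are a step that the two limits leave unreadable from compound 1 to compound 3 and a step that the two limits leave unreadable from compound 2 to compound 3 and neither of them replaces the cyano group itself. No size can be carried over from them, so no step beyond the scatter is expected, in either direction. The estimated step is a step that the limit leaves unreadable from compound 3 to compound 4 and it rests on compound 3 with its limit > 5.83 h alone. Compound 4 is expected to give 6 h in this assay with an estimated range from 3 h to 12 h.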

Compound 4, half-life: > 5.83 h
Compound 4: only a limit was reported (the forecaster's own chance of this, stated with the estimate: 65%); the middle value is on the limit's open side.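

Compound 3 and compound 4 are both reported only as limits in this assay, so the step between them cannot be read. The compounds shown leave open their exact half-lives and whether carbamoyl and cyano differ at all.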